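A few compounds are considered here, and "the series" means these few. Any claim that something is new, unique, unknown or untested is made for them only; others in the source may bear on it.

Compound 1 `Nc1nc(N)c2c(-c3ccsc3)cn([C@@H]3O[C@H](CO)[C@@H](O)[C@H]3O)c2n1` in an ADME assay on MRC5 cells (Homo sapiens), read by MTT assay, with a stated time of 72 h (a higher number here means a weaker inhibitor, a lower number a stronger inhibitor), gives a limit of > 100000 nM. Compound 2 `COc1ncnc2c1c(-c1ccco1)cn2[C@@H]1O[C@H](CO)[C@@H](O)[C@H]1O` in this assay gives 1700 nM. Compound 3 `Cc1nc(N)c2c(-c3ccsc3)cn([C@@H]3O[C@H](CO)[C@@H](O)[C@H]3O)c2n1` in this assay gives a limit of > 100000 nM.

Compound 1 therefore stands only as a limit in this assay, at the limit of > 100000 nM in this assay, at which 2 of the 3 values shown sit. Among the measured compounds shown here, the single measured step that starts from it, a step that the two limits leave unreadable from compound 1 to compound 3, is a methyl in place of amino on an aromatic carbon, and since both of its ends sit at the limit its size cannot be read. The change to compound 4 `Nc1nc(N)c2c(-c3ccco3)cn([C@@H]3O[C@H](CO)[C@@H](O)[C@H]3O)c2n1` is a different one: furan-2-yl in place of thiophen-3-yl on an aromatic carbon. For the measured compounds named here, no measured step exchanges the five-membered aromatic ring on the shared core. Compound 2 does carry furan-2-yl and gives 1700 nM in this assay, but it differs from compound 1 in a second place as well, so its value cannot be read as a step for this ring alone. With compound 1 at the limit and no readable step bearing on the change, the expectation for compound 4 is that it stays weak and most likely returns a limit again. The estimate for compound 4 in this assay is 70000 nM, with a range from 8000 nM to 300000 nM. From compound 1 this is an expected step of an at least 1.4-fold lower number from compound 1 to compound 4 (0.15 log units; that floor lies within the scatter), which cannot be pinned down beyond the scatter.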

Compound 4, half-maximal inhibitory concentration: > 100000 nM
Compound 4: only a limit was reported; the forecaster's own chance of this, stated with the estimate: 60%; at least 1.4-fold (0.15 log units) between middle value and limit.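

In this assay compound 4 gives a limit of > 100000 nM and no exact number. Among the compounds shown here, compound 1 also stands only as a limit, so no step from compound 1 to compound 4 can be read: the limit of > 100000 nM in this assay, at which 3 of the 4 values shown sit. The compounds shown leave open whether furan-2-yl in place of thiophen-3-yl on the shared core changes the number at all, and by how much.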